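Swapping an Aryl Group on a Shared Core

This account rests on a few compounds, and the source may have more. Where it says the series, first, only, none or still open, it means among the compounds named here.

Compound 1 `COc1ccccc1-c1ncnn1-c1cc(OC)c(OC)c(OC)c1` was tested in a functional assay on HeLa cells (Homo sapiens) for antiproliferative activity, read by MTT assay, with a stated time of 72 h; a lower number here means a stronger inhibitor, a higher number a weaker inhibitor. In this assay compound 1 gives only a limit, > 10000 nM, so no number is known for it. Compound 2 `COc1cc(-c2ncnn2-c2cccc(N)c2)cc(OC)c1OC` likewise reaches only the limit of > 10000 nM in this assay. Compound 3 `CCOc1ccccc1-c1ncnn1-c1cc(OC)c(OC)c(OC)c1` also stops at the limit of > 10000 nM in this assay. The single change that links two of these compounds, a step that the two limits leave unreadable from compound 1 to compound 3, therefore cannot be read, since both ends sit at the limit of > 10000 nM in this assay, at which 3 of the 3 values shown sit.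

Compound 4 `COc1cc(-n2ncnc2-c2ccc(Cl)c(Cl)c2)cc(OC)c1OC` differs from compound 1 by 3,4-dichlorophenyl in place of 2-methoxyphenyl on an aromatic carbon. For the measured compounds named here, none of the measured compounds carries a 3,4-dichlorophenyl, and no measured step touches this part of the structure, so nothing here says how large a step to expect in this assay or in which direction. Going by the values given here, what the numbers do show is that every compound so far sits at the limit, and compound 1 itself gives no number that could anchor a shift. Compound 4 is therefore expected to give about 12000 nM, within a broad range from 2000 nM to 50000 nM. For compound 4 the step that this estimate means, a step that the limit leaves unreadable from compound 1 to compound 4, is expected to be small or absent, with a fair chance that only a limit is reported again.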

Compound 4, half-maximal inhibitory concentration: > 10000 nM
Compound 4 gave a limit, no number; the forecaster's own chance of this, stated with the estimate: 65%; the middle value lies beyond the limit too.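

In this assay compound 4 gives only a limit of > 10000 nM and no number. Compound 1 is also a limit, so no step can be read from compound 1 to compound 4: the limit of > 10000 nM in this assay, at which 4 of the 4 values shown sit.

The compounds shown leave open whether any aryl group on the shared core can bring a readable number in this assay at all.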